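The compounds below may be only part of what the source reports. "The series", "measured", "known", "first", "only" and "open" are said of these compounds alone.

Measured in a physicochemical assay for lipophilicity, using the shake flask method, in phosphate buffer, measured as octanol-water partition, with a stated time of 30 min, at pH 7.4; on this read-out lower numbers stand for lower lipophilicity and higher numbers for higher lipophilicity:
Compound 1 `Fc1ccc2c(c1CNc1ncc(Oc3ccccc3)c3nncn13)CCO2`: 3.5
Compound 2 `Cc1ncc(-c2cnc(NCc3c(F)ccc4c3CCO4)c3cn[nH]c(=O)c23)n1C`: 1.9

Compound 2 gives 1.9, the lower of the two numbers, and its gap to compound 1 lies beyond the usual scatter. Compound 3 `CNC(=O)c1ccc(-c2cnc(NCc3c(F)ccc4c3CCO4)c3cn[nH]c(=O)c23)c(C)n1` keeps the core of compound 2 and differs in one place: 2-methyl-6-(methylcarbamoyl)pyridin-3-yl in place of 1,2-dimethyl-1H-imidazol-5-yl on an aromatic carbon. In words, 2-methyl-6-(methylcarbamoyl)pyridin-3-yl stands in place of 1,2-dimethyl-1H-imidazol-5-yl on an aromatic carbon. Within the data shown here, no pair of measured compounds shows this kind of change, so any expectation in this assay is a rough one. The expected step is a small rise, a number 0.40 log units higher from compound 2 to compound 3 (beyond the scatter). For compound 3 the estimated value is 2.3, with a range of 1.8 to 2.8.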

Compound 3, distribution coefficient: 2.9
For compound 3 the middle estimate is 0.60 log units below the measured one; the whole stated range lies below it.
By their numbers in this assay, from the lowest: compound 2; then compound 3; then compound 1.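

In this assay, 2-methyl-6-(methylcarbamoyl)pyridin-3-yl in place of 1,2-dimethyl-1H-imidazol-5-yl gives a number 1.00 log units higher from compound 2 to compound 3 (beyond the scatter) on the shared core. The read-out therefore moves with the group on this aromatic carbon, although neither group carries a net charge. Nothing measured here accounts for the rise.

The compounds shown leave open whether the step follows the methylcarbamoyl group or the six-membered ring that carries it. Going by these compounds, how the read-out would respond to an amine or a carboxylic acid at this position also remains unknown.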